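The source may report more compounds than this note shows. Statements on the series, on what has been measured and on what is new or still open speak of the compounds shown alone.

In a functional assay on CCRF-CEM cells (Homo sapiens) for inhibition (a lower number here means a stronger inhibitor, a higher number a weaker inhibitor), compound 1 (`O=C1/C(=C/c2cccc(Br)c2)CCCc2ccccc21`) gives 8900 nM and compound 2 (`O=C1CCCCC/C1=C\c1cccc(F)c1`) gives 224000 nM. Compound 2 therefore holds the higher number of the two and is the weaker inhibitor, and its gap to compound 1 lies beyond the scatter. These two compounds differ in more than one place, so their values do not isolate the effect of any single change. Compound 3 (`COc1cccc(/C=C2\CCCCCC2=O)c1`) follows from compound 2 with methoxy in place of fluoro on an aromatic carbon. Within the data shown here, no measured step covers this exchange, so no change beyond the scatter is expected in this assay, and no direction is favoured with confidence. The estimated 1.2-fold lower number from compound 2 to compound 3 (0.09 log units; within the scatter) stays small on that basis. For compound 3 the expected value is 180000 nM, with an estimated range of 70000 nM to 450000 nM.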

Compound 3, half-maximal inhibitory concentration: 128000 nM
For compound 3 the middle estimate is 1.4-fold (0.15 log units) above the measured one, within the range that was stated.
By their numbers in this assay, from the lowest: compound 1; then compounds 3 and 2 (each within the scatter of the next).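

In this assay, among these compounds, the exchange of fluoro for methoxy on an aromatic carbon of the six-membered aromatic ring gives a 1.8-fold lower number from compound 2 to compound 3 (0.24 log units; within the scatter), the first step that isolates a single change. At this position, meta to a group of 9 heavy atoms, the assay therefore does not separate the two groups, although 2 heavy atoms enter where 1 leaves and the entering methoxy carries a hydrogen-bond acceptor. No supporting data bear on why the two groups read alike here.

On these data alone, whether an amine or a carboxylic acid at this position would shift the number beyond the scatter remains open. Also open, as far as these compounds go, is whether the same exchange of fluoro for methoxy would read alike on the core of compound 1.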